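This account rests on a few compounds, and the source may have more. Where it says the series, first, only, none or still open, it means among the compounds named here.

Measured compounds in an ADME assay on MT4 cells (Homo sapiens) for cytotoxicity, read by MTT assay; on this read-out higher numbers stand for lower toxicity in this test and lower numbers for higher toxicity in this test:

Compound 1 `O=C(CSc1nccn1-c1ccc(Cl)cc1)Nc1ccccc1Br` gives a limit of the assay, > 300000 nM; this is described by the limit of > 300000 nM in this assay, at which 1 of the 3 values shown sits.
Compound 2 `COc1ccc(-n2ccnc2SCC(=O)Nc2ccccc2Cl)cc1` gives a limit of the assay, > 334000 nM; this is described by the limit of > 334000 nM in this assay, at which 1 of the 3 values shown sits.
Compound 3 `Cc1ccc(-n2ccnc2SCC(=O)Nc2ccccc2Cl)cc1` gives 33700 nM.

For the measured compounds named here, compound 3 is thus the only member of the series with a number in this assay; the other two values are limits. Going by the values given here, the one measured step that reaches a number is an at least 9.9-fold lower number from compound 2 to compound 3 (0.99 log units; beyond the scatter), and it is the only step that changes the substituent on the aryl ring attached to the shared core.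

Compound 4 `O=C(CSc1nccn1-c1ccc(Cl)cc1)Nc1ccccc1Cl` is not yet measured. It differs from compound 3 by chloro in place of methyl on an aromatic carbon. Among the compounds with values here, no measured step covers chloro in place of methyl at this position. Within the data shown here, the one related step, an at least 9.9-fold lower number from compound 2 to compound 3 (0.99 log units; beyond the scatter), shows that a change at this position can move the number beyond the scatter, so a step beyond the scatter in either direction cannot be excluded. Compound 1 carries the same 4-chlorophenyl group and sits at a limit, but it also differs from compound 4 elsewhere, so it offers only a loose pointer. Compound 4 is estimated at 100000 nM, with a range from 20000 nM to 400000 nM, which corresponds to an expected step of a 3.0-fold higher number from compound 3 to compound 4 (0.47 log units; beyond the scatter).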

Compound 4, half-maximal cytotoxic concentration: > 330000 nM
Compound 4: a limit, no number (the forecaster's own chance of this, stated with the estimate: 40%); middle value at least 3.3-fold (0.51 log units) away from the limit.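

In this assay, the change from 4-methylphenyl to 4-chlorophenyl gives an at least 9.7-fold higher number from compound 3 to compound 4 (0.99 log units; beyond the scatter), so moving away from methyl at this position now raises the number with a second group and not only with methoxy. Among compound 2, compound 3 and compound 4, which differ only at this position, methyl is the only group that gives a number, while methoxy and chloro both end at limits of the assay. The result for compound 4 is a limit and not a number, and the steps to it from compound 1 and compound 2 cannot be read: the limit of > 330000 nM in this assay, at which 1 of the 4 values shown sits.

Going by these compounds, how far compound 2 and compound 4 lie beyond their limits remains open, so no order can be given between methoxy and chloro at this position. On these data alone, it is also open whether the lower number in this assay is specific to methyl or would also appear with a longer chain such as ethyl, or with an amine, at the same position.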